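This account rests on a few compounds, and the source may have more. Where it says the series, first, only, none or still open, it means among the compounds named here.

Measured in an assay on HEK293 cells for displacement of a labelled ligand from Type-2 angiotensin II receptor (Homo sapiens); on this read-out lower numbers stand for stronger inhibition and higher numbers for weaker inhibition:
- Compound 1 `CCCCS(=O)(=O)NNC(=O)[C@@H](NC(=O)c1cccc(Cn2ccnc2)c1)[C@@H](C)CC`; compound 1 reads > 100000 nM, a limit of the assay and not a number.
- Compound 2 `CCCCS(=O)(=O)NC(=O)[C@@H](NC(=O)c1cccc(Cn2ccnc2)c1)[C@@H](C)CC`; compound 2 gives 9900 nM.
- Compound 3 `CC[C@H](C)[C@H](NC(=O)c1cccc(Cn2ccnc2)c1)C(=O)NNS(=O)(=O)c1ccc(C)cc1`; compound 3 gives 29000 nM.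

Compound 3 stands highest of the two numbers; its nearest neighbour is compound 2, with a 2.9-fold higher number from compound 2 to compound 3 (0.47 log units; beyond the scatter). Compound 4 `CC[C@H](C)[C@H](NC(=O)c1cccc(Cn2ccnc2)c1)C(=O)NNS(=O)(=O)c1c(C)cc(C)cc1C` differs from compound 3 only by 2,4,6-trimethylphenyl in place of 4-methylphenyl on a sulfonyl sulfur. Among the measured compounds shown here, the single measured step on the sulfonyl sulfur is an at least 3.4-fold lower number from compound 1 to compound 3 (0.53 log units; beyond the scatter), and compound 1 sits at a limit (the limit of > 100000 nM in this assay, at which 1 of the 3 values shown sits), so the size of that step is open. For the measured compounds named here, no measured step adds methyls to an aryl on this position. In this assay a step of no change at the digits printed from compound 3 to compound 4 (within the scatter) is therefore expected, nothing beyond the scatter. Compound 4 is estimated at 29000 nM, within a range of 10000 nM to 90000 nM.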

Compound 4, inhibition constant: 8500 nM
Compound 4: middle estimate off by 3.4-fold (0.53 log units), on the high side, outside the stated range (below it).
By their numbers in this assay, from the lowest: compounds 4 and 2 (each within the scatter of the next); then compound 3. At a limit, above all of these: compound 1.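

Added methyls on the aryl group matter at this position: 2,4,6-trimethylphenyl in place of 4-methylphenyl on the sulfonyl sulfur gives a 3.4-fold lower number from compound 3 to compound 4 (0.53 log units; beyond the scatter), the first measured step between two aryl groups here. Against butyl, the same aryl group gives an at least 11-fold lower number from compound 1 to compound 4 (1.07 log units; beyond the scatter). The value of compound 1 is a limit and not a number, so that step gives only a bound: the limit of > 100000 nM in this assay, at which 1 of the 4 values shown sits.

Which of the added methyls carries the step remains open. So does the outcome with a naphthyl or 4-chlorophenyl group on the sulfonyl sulfur.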